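A few compounds are considered here, and "the series" means these few. Any claim that something is new, unique, unknown or untested is made for them only; others in the source may bear on it.

Among the measured compounds shown here, in a functional assay on MDA-MB-231 cells (Homo sapiens) for inhibition, read by MTT assay, with a stated time of 72 h (a lower number here means a stronger inhibitor, a higher number a weaker inhibitor), compound 2 (`CO[C@@H](c1ccccc1)[C@H]1O[C@@H]2CC(=O)O[C@@H]2[C@H]1O`) gives 130 nM and stands second highest of the three numbers so far. Compound 3 (`CO[C@H](c1ccccc1)[C@H]1O[C@@H]2CC(=O)O[C@@H]2[C@H]1O`) lies lower at 64 nM and compound 1 (`CO[C@@H]1[C@H]2OC(=O)C[C@H]2O[C@@H]1[C@@H](O)c1ccccc1`) lies far higher at 35200 nM in the same read-out.

Compound 4 (`CO[C@@H]1[C@H]2OC(=O)C[C@H]2O[C@@H]1[C@@H](OC)c1ccccc1`) comes from compound 2 by methyl in place of hydrogen on an oxygen on a saturated carbon in the form of methyl in place of hydrogen on an oxygen on a saturated carbon, that is hydroxy to methoxy. For the measured compounds named here, the one measured step, a 2.0-fold lower number from compound 2 to compound 3 (0.31 log units; beyond the scatter) (modest), comes from the fact that compounds 2 and 3 differ only in the configuration as drawn and so does not test this change. Going by the values given here, no measured step covers hydroxy to methoxy at this place. The nearest guide is compound 1, which already holds a methoxy there and gives 35200 nM while compound 2 gives 130 nM with a free hydroxy there. That contrast is only indirect, so the expectation stays wide.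

A higher number is expected in this assay with a 12-fold higher number from compound 2 to compound 4 (1.06 log units; beyond the scatter) as the estimated step beyond the scatter. For compound 4 the estimate is 1500 nM with an expected range from 150 nM to 15000 nM in this read-out.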

Compound 4, half-maximal inhibitory concentration: 2650 nM
Estimate against measurement, compound 4: 1.8-fold (0.25 log units) below; low and high end bracket the measured number.
By their numbers in this assay, from the lowest: compound 3; then compound 2; then compound 4; then compound 1.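

In this assay the same exchange, methyl in place of hydrogen on an oxygen on a saturated carbon, runs in opposite directions depending on which hydroxy is capped: a 20-fold higher number from compound 2 to compound 4 (1.31 log units; beyond the scatter) and a 13-fold lower number from compound 1 to compound 4 (1.12 log units; beyond the scatter) are both large steps. Among the compounds shown here, the earlier compounds showed only a configuration step, so this is the first direct reading that the free hydroxy of compound 2 matters to this read-out, and that the free hydroxy of compound 1 does not help it, since capping that group lowers the number. Hydroxy to methoxy therefore has no single sign in this series, and neither step comes with a measured reason.

Going by these compounds, what remains open is whether the rise on capping the hydroxy of compound 2 is specific to methyl, or whether a longer chain such as ethyl on that oxygen, or an amine in place of the hydroxy, would give a different number. Also open, on these data alone, is how the configuration at the methoxy-bearing chain carbon reads in compound 4, given the modest step of a 2.0-fold lower number from compound 2 to compound 3 (0.31 log units; beyond the scatter) seen with a free hydroxy present.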